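Fluoro for chloro in a series held at limits

The source may hold more compounds than are shown below. What is called first, only, known or untested is meant among the compounds shown, and "the series" means these compounds.

Compound 1 `O=C(Nc1cccc(-c2nc3ccccc3s2)c1)c1cc([N+](=O)[O-])ccc1Cl`: > 27000 nM
Compound 2 `COc1ccc(-c2nc3ccccc3s2)cc1NC(=O)c1cc([N+](=O)[O-])ccc1Cl`: > 25000 nM
Compound 3 `O=C(Nc1cc(-c2nc3ccccc3s2)ccc1Cl)c1cc([N+](=O)[O-])ccc1Cl`: > 25000 nM

In an ADME assay on Raji cells (Homo sapiens) for cytotoxicity, with a stated time of 72 h (a higher number here means that more compound is needed for the effect, a lower number that less compound is needed), all three entries are limits and not numbers. Compound 3 stands at > 25000 nM, which is a limit. Compound 4 `O=C(Nc1cc(-c2nc3ccccc3s2)ccc1F)c1cc([N+](=O)[O-])ccc1Cl` follows from compound 3 by one change: fluoro in place of chloro on an aromatic carbon. Two measured steps alter the same substituent: a step that the two limits leave unreadable from compound 1 to compound 3 and a step that the two limits leave unreadable from compound 2 to compound 3. Neither gives a size, and the same holds for a step that the two limits leave unreadable from compound 1 to compound 2. No step beyond the scatter is therefore expected in this assay, and no direction can be argued. The estimated outcome is a step that the limit leaves unreadable from compound 3 to compound 4. Compound 4 is expected near 27000 nM, with an estimated range of 14000 nM to 50000 nM, and will most likely be reported as a limit again.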

Compound 4, half-maximal effective concentration: > 25000 nM
Compound 4: no number, only a limit (the forecaster's own chance of this, stated with the estimate: 85%); the middle value lies beyond the limit too.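

In this assay compound 4 gives > 25000 nM, which is a limit, so its steps from compounds 1, 2 and 3 cannot be read. From the compounds shown here alone, whether hydrogen, methoxy, chloro and fluoro differ at all in this assay stays open: none of the four compounds has a number.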